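Cytotoxicity notes on a small fused-ring series

The compounds below may be only part of what the source reports. "The series", "measured", "known", "first", "only" and "open" are said of these compounds alone.

Compound 1 `Brc1ccc2[nH]c(-c3cn(-c4ccccc4)nc3-c3ccccc3)nc2c1` is the reference point. In an ADME assay on HaCaT cells (Homo sapiens) for cytotoxicity, read by MTT assay, with a stated time of 48 h (on this read-out higher numbers stand for weaker inhibition and lower numbers for stronger inhibition), compound 1 gives > 50000 nM, a limit of the assay rather than a number. Compound 2 `COc1ccc2[nH]c(-c3cn(-c4ccccc4)nc3-c3ccccc3)nc2c1` carries methoxy in place of bromo on an aromatic carbon. In this assay compound 2 gives > 50000 nM, again a limit. The step that the two limits leave unreadable from compound 1 to compound 2 cannot be sized because the limit of > 50000 nM in this assay, at which 2 of the 3 values shown sit, caps both readings.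

Compound 3 `Fc1ccc(-c2nn(-c3ccccc3)cc2-c2nc3cc(Br)ccc3[nH]2)cc1` differs from compound 1 by fluoro in place of hydrogen on an aromatic carbon. In this assay, within the data shown here, compound 3 gives 21800 nM, the only genuine number in the set; the step of an at least 2.2-fold lower number from compound 1 to compound 3 (0.36 log units; beyond the scatter) is the one readable comparison.

Compound 4 `COc1ccc2[nH]c(-c3cn(-c4ccccc4)nc3-c3ccc(F)cc3)nc2c1` is not yet measured. Relative to compound 3 it carries methoxy in place of bromo on an aromatic carbon, the same change as that from compound 1 to compound 2, at the same place. That earlier step is unreadable, so it gives no direction for the present case. The expectation for compound 4 is a step of a 1.6-fold higher number from compound 3 to compound 4 (0.21 log units; within the scatter) in this assay, with a real chance that only a limit is returned. The estimated value for compound 4 is 35000 nM.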

Compound 4, half-maximal inhibitory concentration: > 50000 nM
Compound 4: no number, only a limit; the forecaster's own chance of this, stated with the estimate: 55%; middle value at least 1.4-fold (0.15 log units) from the limit.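

On the core of compound 3, methoxy in place of bromo gives an at least 2.2-fold higher number from compound 3 to compound 4 (0.36 log units; beyond the scatter), the one readable size for this change in the series. In this assay compound 4 gives > 50000 nM, a limit and not a number. This does not show that the change carries from one core to another, since the same change on the core of compound 1 and the fluoro step from compound 2 to compound 4 cannot be read, because both ends of each pair are capped: the limit of > 50000 nM in this assay, at which 3 of the 4 values shown sit.

As far as these compounds go, whether methoxy has the same direction and size on a core without the fluoro group remains open, as does whether fluoro in place of hydrogen lowers the number when methoxy is present. Also open, from the compounds shown here alone, is how an amine or a carboxylic acid in place of bromo on the same aromatic carbon would read, and whether either would give a number rather than a limit.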